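Hydrogen in Place of Ethyl, Carried to a Second Core

This account rests on a few compounds, and the source may have more. Where it says the series, first, only, none or still open, it means among the compounds named here.

Compound 1 `CCOC(=O)C(=O)CC(=O)/C=C/c1cn(Cc2ccccc2)c2ccccc12`: > 40000 nM
Compound 2 `O=C(/C=C/c1cn(Cc2ccccc2)c2ccccc12)CC(=O)C(=O)O`: > 40000 nM
Compound 3 `CCOC(=O)C(=O)CC(=O)/C=C/c1cc(C(=O)c2ccccc2F)c[nH]1`: > 40000 nM

In an ADME assay on HeLa cells (Homo sapiens) for inhibition, read by MTT assay, with a stated time of 48 h (a higher number here means a weaker inhibitor, a lower number a stronger inhibitor), compound 1 gives only a limit, > 40000 nM. Compound 2 likewise gives only a limit in this assay, > 40000 nM. The step that the two limits leave unreadable from compound 1 to compound 2 is therefore not readable, since both values sit at the limit of > 40000 nM in this assay, at which 3 of the 3 values shown sit. The change itself is hydrogen in place of ethyl on an oxygen next to a carbonyl group.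

Compound 3 also gives only a limit in this assay, > 40000 nM. Its difference from compound 1 lies in the core, and that difference is not broken down here. Compound 4 `O=C(/C=C/c1cc(C(=O)c2ccccc2F)c[nH]1)CC(=O)C(=O)O` carries the same change on the core of compound 3: hydrogen in place of ethyl on an oxygen next to a carbonyl group.

With three limits and no readable step, the account rests on the limit of > 40000 nM in this assay, at which 3 of the 3 values shown sit, alone. The step that the limit leaves unreadable from compound 3 to compound 4 is expected to be unreadable as well, so compound 4 is estimated at 60000 nM, most likely again only a limit.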

Compound 4, half-maximal inhibitory concentration: > 40000 nM
Compound 4 was reported as a limit (the forecaster's own chance of this, stated with the estimate: 85%); the middle value does not contradict the limit.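

No size can be read for the step between compound 3 and compound 4, since both are limits in this assay and not numbers: the limit of > 40000 nM in this assay, at which 4 of the 4 values shown sit.

The compounds shown leave open whether hydrogen in place of ethyl changes inhibition on either core.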